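Chloro to Acetoxy on the Side Chain: What to Expect

The compounds below may be only part of what the source reports. "The series", "measured", "known", "first", "only" and "open" are said of these compounds alone.

Measured compounds:
compound 1 `O=C(/C=C/C1CCCCC1)c1ccccc1` — 21000 nM
compound 2 `O=C(/C(=C/C1CCCCC1)CCl)c1ccccc1` — 30000 nM
compound 3 `O=C(/C(=C/c1ccccc1)CCl)c1ccccc1` — 23000 nM

All three numbers come from a functional assay on HeLa cells (Homo sapiens) for inhibition, read by sulforhodamine B assay, with a stated time of 48 h (on this read-out lower numbers stand for stronger inhibition of growth and higher numbers for weaker inhibition of growth), and lie within the usual scatter of one another. Compound 2 stands among them with no step beyond the scatter to either neighbour: its distance to compound 3 is a 1.3-fold lower number from compound 2 to compound 3 (0.12 log units; within the scatter), and its distance to compound 1 is likewise within the scatter, so no ordering can be read from these three.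

Compound 4 `CC(=O)OC/C(=C\C1CCCCC1)C(=O)c1ccccc1` differs from compound 2 in one place: acetoxy in place of chloro on a saturated chain carbon bound to a double-bonded chain carbon. Among the compounds with values here, none of the measured steps touches this position. Within the data shown here, the only step between compounds that differ in one place, a 1.3-fold lower number from compound 2 to compound 3 (0.12 log units; within the scatter), swaps phenyl for cyclohexyl on a double-bonded chain carbon and stays within the scatter, so it says nothing direct about the chloro-to-acetoxy change. Among the measured compounds shown here, with every measured number sitting in one narrow band and no bearing step, the expected step from compound 2 to compound 4 in this assay is none beyond the scatter, no change at the digits printed from compound 2 to compound 4 (within the scatter). Compound 4 is therefore estimated at 30000 nM, within a range from 10000 nM to 90000 nM.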

Compound 4, concentration for 50% growth inhibition: 21000 nM
Compound 4: middle estimate off by 1.4-fold (0.15 log units), on the high side; the measured number falls inside the stated range.
By their numbers in this assay, from the lowest: compounds 1, 4, 3 and 2 (each within the scatter of the next).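

The chloro position now has a direct reading: in this assay, acetoxy in place of chloro on a saturated chain carbon bound to a double-bonded chain carbon gives a 1.4-fold lower number from compound 2 to compound 4 (0.15 log units; within the scatter). The earlier compounds shown here held no step at this position, and this one shows that acetoxy, with four heavy atoms against one and two hydrogen-bond acceptors against none, can stand there without a step beyond the scatter. Nothing measured here accounts for this result.

On these data alone, it remains open whether an amine or a carboxylic acid on this same carbon would give a step beyond the scatter. As far as these compounds go, it also remains open whether acetoxy in place of chloro would read the same way on compound 3, which carries phenyl where compound 2 carries cyclohexyl.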